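The source may hold more compounds than are shown below. What is called first, only, known or untested is meant among the compounds shown, and "the series" means these compounds.

Compound 1, `N=C(NCCCc1c[nH]cn1)NCCC(c1ccccc1)c1ccccn1`: 1
Compound 2, `N=C(NCCCc1c[nH]cn1)NCCC(c1ccc(F)cc1)c1ccccn1`: 1
Compound 3, `N=C(NCCCc1c[nH]cn1)NCCC(c1ccc(Cl)cc1)c1ccccn1`: 1

All three were measured in a functional assay on cardiac atrium for agonist activity at histamine H2 receptor (Cavia porcellus); a higher number here means a larger maximal response, a lower number a smaller maximal response. Compound 3 stands level with compounds 1 and 2, and its steps to both lie within the scatter: no change at the digits printed from compound 1 to compound 3 (within the scatter) and no change at the digits printed from compound 2 to compound 3 (within the scatter). Compound 4, `N=C(NCCCc1c[nH]cn1)NCCC(c1ccc(Br)cc1)c1ccccn1`, is the next one to be measured in this assay. The change from compound 3 is bromo in place of chloro on an aromatic carbon.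

For the measured compounds named here, the steps that bear on this change are the halogen swaps on the same aromatic carbon: no change at the digits printed from compound 1 to compound 2 (within the scatter), no change at the digits printed from compound 1 to compound 3 (within the scatter) and no change at the digits printed from compound 2 to compound 3 (within the scatter). None of them moved the read-out beyond the scatter, so no step beyond the scatter is expected here either: no change at the digits printed from compound 3 to compound 4 (within the scatter). Compound 4 is therefore estimated to give 1, within 0.85 to 1.05.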

Compound 4, intrinsic activity: the largest response reached, as a fraction of the reference agonist's: 1
The estimate for compound 4 equals the measured number at the digits printed; the range from low to high includes it.
By their numbers in this assay, from the lowest: compounds 1, 2, 3 and 4 (each within the scatter of the next).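

Bromo, on an aromatic carbon para to a large group, takes the halogen series one member further, and in this assay its swap for chloro gives no change at the digits printed from compound 3 to compound 4 (within the scatter). Bromo in place of fluoro gives no change at the digits printed from compound 2 to compound 4 (within the scatter), and bromo in place of hydrogen gives no change at the digits printed from compound 1 to compound 4 (within the scatter), so hydrogen and all three halogens stand level at this position. Nothing at hand accounts for this level read-out.

The compounds shown leave open whether a group other than a halogen, such as an amine, a carboxylic acid or a methoxy group, would stay level here.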